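The source may hold more compounds than are shown below. What is called first, only, known or untested is meant among the compounds shown, and "the series" means these compounds.

In a functional assay on HepG2 cells (Homo sapiens) for inhibition, read by MTT assay, with a stated time of 72 h (on this read-out lower numbers stand for stronger inhibition and higher numbers for weaker inhibition), three compounds sharing one core have been measured. Compound 1 (`Cc1ccc(NC(=O)C2CCN(C/C=C/c3ccccc3)CC2)cc1`) gives 33900 nM, compound 2 (`CCc1ccc(NC(=O)C2CCN(C/C=C/c3ccccc3)CC2)cc1`) gives 23300 nM, and compound 3 (`CC(C)c1ccc(NC(=O)C2CCN(C/C=C/c3ccccc3)CC2)cc1`) gives 12200 nM. Compound 3 is clearly separated only from compound 1: a 2.8-fold lower number from compound 1 to compound 3 (0.44 log units; beyond the scatter) lies beyond the scatter, whereas a 1.9-fold lower number from compound 2 to compound 3 (0.28 log units; within the scatter) lies within it, as does a 1.5-fold lower number from compound 1 to compound 2 (0.16 log units; within the scatter).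

Compound 4 (`COc1ccccc1NC(=O)C1CCN(C/C=C/c2ccccc2)CC1`) brings a larger structural change, replacing the whole group on the amide-type nitrogen: 2-methoxyphenyl in place of 4-isopropylphenyl on an amide-type nitrogen. The measured steps only lengthen or branch a small carbon group, from methyl to isopropyl. None of them tests a methoxy group, so they bear on this change only indirectly. For the measured compounds named here, the one step beyond the scatter, a 2.8-fold lower number from compound 1 to compound 3 (0.44 log units; beyond the scatter), came with the arrival of isopropyl, and compound 4 has no isopropyl. A modest move to a higher number in this assay is therefore expected, though its size is quite uncertain. The expected step is a 2.3-fold higher number from compound 3 to compound 4 (0.36 log units; beyond the scatter). Compound 4 is estimated at 28000 nM, with an expected range of 11000 nM to 70000 nM.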

Compound 4, half-maximal inhibitory concentration: 91200 nM
Compound 4: middle estimate off by 3.3-fold (0.51 log units), on the low side; the measured number lies above the stated range.
By their numbers in this assay, from the lowest: compounds 3, 2 and 1 (each within the scatter of the next, the first and the last beyond it); then compound 4.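

In this assay, putting 2-methoxyphenyl on the amide-type nitrogen gives a higher number than every earlier group, with all three steps beyond the scatter: one of them is (a 7.5-fold higher number from compound 3 to compound 4 (0.87 log units; beyond the scatter)), another (a 3.9-fold higher number from compound 2 to compound 4 (0.59 log units; beyond the scatter)), and the third (a 2.7-fold higher number from compound 1 to compound 4 (0.43 log units; beyond the scatter)). The earlier compounds shown here, which carry only a small carbon group at the 4 place of the ring, showed how little the number moved among methyl, ethyl and isopropyl; compound 4 shows that this position can respond far more strongly, with its largest step exceeding any seen among those three. No measurement here explains why this change raises the number so much.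

As far as these compounds go, the change alters both the kind of group and its place on the ring, so it remains open whether the higher number goes with the methoxy group or with the 2 place, a question that 4-methoxyphenyl and 2-isopropylphenyl on the same core would help to separate. From the compounds shown here alone, it also remains open how this position would respond to an amine, a carboxylic acid or a longer carbon chain on the ring.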